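Sulfanyl side-chain change from compound 1 to compound 4

The source may report more compounds than this note shows. Statements on the series, on what has been measured and on what is new or still open speak of the compounds shown alone.

Of the compounds shown here, three have been measured in a functional assay on MCF7 cells (Homo sapiens) for inhibition, read by MTT assay, with a stated time of 72 h; a lower number here means a stronger inhibitor, a higher number a weaker inhibitor. Compound 1 `Cc1cc(Nc2cc(-c3ccccc3)[nH]n2)n2nc(SCCCc3ccccc3)nc2n1` gives 3900 nM. Compound 2 `Cc1ccc(CSc2nc3nc(C)cc(Nc4cc(-c5ccccc5)[nH]n4)n3n2)cc1` gives 7290 nM, and compound 3 `CCCCCc1c(C)nc2nc(SCc3ccc(Cl)cc3)nn2c1Nc1cc(-c2ccccc2)[nH]n1` gives 6390 nM. On these numbers compound 1 has the lowest value of the three, but its gaps to compound 3 and to compound 2 both lie within the scatter, so no order among the three can be drawn. Among the compounds with values here, the one step between compounds that differ in a single place, a 1.9-fold higher number from compound 1 to compound 2 (0.27 log units; within the scatter), replaced phenethyl with 4-methylphenyl on a saturated chain carbon bound to a sulfur and stayed within the scatter.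

Compound 4 `Cc1cc(Nc2cc(-c3ccccc3)[nH]n2)n2nc(SCc3nc4ccccc4[nH]3)nc2n1` has not yet been measured. Relative to compound 1 the change is 1H-benzimidazol-2-yl in place of phenethyl on a saturated chain carbon bound to a sulfur. Within the data shown here, the only measured step at the same place, a 1.9-fold higher number from compound 1 to compound 2 (0.27 log units; within the scatter), hardly moved the number. Among the measured compounds shown here, no measured compound carries a group with a hydrogen-bond donor or acceptor at this position, so the data give no direct guide for the entering 1H-benzimidazol-2-yl. The expectation is therefore a step not larger than the scatter, a 1.2-fold higher number from compound 1 to compound 4 (0.06 log units; within the scatter). Compound 4 is estimated at 4500 nM in this assay, with a range from 1500 nM to 13000 nM.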

Compound 4, half-maximal inhibitory concentration: 2730 nM
Beside the measured number, compound 4's estimate is 1.6-fold (0.22 log units) above it, and the stated range covers the measured number.
By their numbers in this assay, from the lowest: compounds 4, 1, 3 and 2 (each within the scatter of the next, the first and the last beyond it).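

Within the data shown here, at this sulfanyl position the side chain can carry 1H-benzimidazol-2-yl, the first group with a hydrogen-bond donor and acceptor here, and in this assay the step from phenethyl stays small (a 1.4-fold lower number from compound 1 to compound 4 (0.15 log units; within the scatter)). Set against 4-methylphenyl, the same group gives the first step at this place that clears the scatter (a 2.7-fold lower number from compound 2 to compound 4 (0.43 log units; beyond the scatter)), though only modestly, so the choice of side chain now has a measurable but small effect on the number, and only for this one pair. No supporting measurement bears on why the number moves in this way.

The compounds shown leave open whether the ring hydrogen of 1H-benzimidazol-2-yl matters at all, a question that 1-methyl-1H-benzimidazol-2-yl on the same sulfanyl chain would address directly. They also leave open how this position responds to a chain ending in an amine or a carboxylic acid, and whether any side chain here can move the number well beyond the modest step seen so far.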